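Chloro in place of nitro on the aromatic ring

This account rests on a few compounds, and the source may have more. Where it says the series, first, only, none or still open, it means among the compounds named here.

Two compounds of this series have been run in a functional assay on CHO-K1 cells for antagonist activity at adenosine receptor A2b (Homo sapiens), read by 33P incorporation, with a stated time of 20 min, in the presence of a further agent that is not named here (on this read-out lower numbers stand for stronger inhibition and higher numbers for weaker inhibition), so far. Compound 1 `COc1ccc(Nc2nc3c(Cl)ncnc3s2)cc1` gives > 10000 nM, which is a limit of the assay and not a number. Compound 2 `O=[N+]([O-])c1ccc(Nc2nc3c(N4CCCC4)ncnc3s2)cc1` gives > 10000 nM, again a limit rather than a number. Among the compounds with values here, compound 2 therefore stands at the same point as the only other value shown, both resting at the limit (the limit of > 10000 nM in this assay, at which 2 of the 2 values shown sit); no order between the two can be read from this.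

Compound 3 `Clc1ccc(Nc2nc3c(N4CCCC4)ncnc3s2)cc1` is the next candidate. It differs from compound 2 by chloro in place of nitro on an aromatic carbon, para to a large group. Within the data shown here, no measured step exists between compounds differing in one place, so there is no direct guide to the size of this change. Given that compound 2 sits at the limit, compound 3 is expected to show no step beyond the scatter, a step that the limit leaves unreadable from compound 2 to compound 3, and most likely to return another limit. The estimate for compound 3 is 15000 nM, with a range from 4000 nM to 60000 nM.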

Compound 3, inhibition constant: > 10000 nM
Compound 3: only a limit was reported; the forecaster's own chance of this, stated with the estimate: 80%; the middle value is on the limit's open side.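

No step can be read from compound 2 to compound 3, as both values are limits of the assay and not numbers: the limit of > 10000 nM in this assay, at which 3 of the 3 values shown sit. The compounds shown leave open how chloro and nitro compare in this assay and what on the shared core would bring a value inside the limit.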